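Trimming the Side Chain: From Phenethyl to Propyl

This account rests on a few compounds, and the source may have more. Where it says the series, first, only, none or still open, it means among the compounds named here.

In a functional assay on HT-29 cells (Homo sapiens) for cytotoxicity, read by sulforhodamine B assay, with a stated time of 2 days, tested at 100 uM (on this read-out higher numbers stand for more inhibition at the one concentration tested (going by the name of the read-out) and lower numbers for less inhibition), compound 1 `O=C(Nn1c(-c2ccccc2)nc2c(-c3ccc(Cl)cc3)n[nH]c2c1=O)c1ccccc1` gives 92%. Compound 2 `O=C(Nn1c(CCc2ccccc2)nc2c(-c3ccc(Cl)cc3)n[nH]c2c1=O)c1ccccc1` has a phenethyl group where compound 1 has phenyl, and in this assay compound 2 gives 86.5%, a number within the usual scatter of compound 1. Compound 3 `CCCc1nc2c(-c3ccc(Cl)cc3)n[nH]c2c(=O)n1NC(=O)c1ccccc1` carries one change relative to compound 2: methyl in place of phenyl on a saturated chain carbon, two bonds along the chain from an aromatic carbon. Among the measured compounds shown here, only one measured step bears on this change, a number 5.5 percentage points lower from compound 1 to compound 2 (within the scatter), and it stayed within the scatter. The expected step is therefore a number 6.5 percentage points lower from compound 2 to compound 3 (within the scatter), no larger than the scatter. Compound 3 is estimated at 80% in this assay, between 60% and 95%.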

Compound 3, a percentage reported as inhibition, at one concentration (the size of the read-out at that concentration, not a potency): 91.1%
Compound 3: middle estimate off by 11.1 percentage points, on the low side; the range from low to high includes it.
By their numbers in this assay, from the lowest: compounds 2, 3 and 1 (each within the scatter of the next).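

Going from phenethyl to propyl gives a number 4.6 percentage points higher from compound 2 to compound 3 (within the scatter) in this assay, so the phenyl at the end of the chain can be lost with no step beyond the scatter. Propyl in place of phenyl on an aromatic carbon gives a number 0.9 percentage points lower from compound 1 to compound 3 (within the scatter) in this assay, so a plain saturated chain and a directly attached phenyl read alike at this position. Nothing available explains this result.

From the compounds shown here alone, whether an amine or a carboxylic acid at the end of the propyl chain, or a longer chain such as hexyl, would move this read-out stays open. Going by these compounds, with a single tested concentration, potency also stays open.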